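Swapping bromo for fluoro on the anilide ring

The compounds below may be only part of what the source reports. "The series", "measured", "known", "first", "only" and "open" are said of these compounds alone.

Compound 2, `CN(C)C(=O)c1cc2cnc(Nc3ccc(NC(=O)C4(C(=O)Nc5ccc(Br)cc5)CC4)cc3)nc2n1C1CCCC1`, is the reference point here. For the measured compounds named here, in a functional assay on NCI-H460 cells (Homo sapiens) for inhibition, read by CCK-8 assay, with a stated time of 72 h, tested at 10 uM (on this read-out higher numbers stand for more inhibition of growth at the one concentration tested and lower numbers for less inhibition of growth), compound 2 gives 96.4%, the highest of the three numbers so far. Compound 1, `CN(C)C(=O)c1cc2cnc(Nc3ccc(NC(=O)C4(C(=O)Nc5cccc(O)c5)CC4)cc3)nc2n1C1CCCC1`, gives 94.9% in this assay; the change between them is a number 1.5 percentage points higher from compound 1 to compound 2 (within the scatter), which is within the scatter and so counts as no real change. Compound 3, `Nc1ccc(NC(=O)C2(C(=O)Nc3ccc(F)cc3)CC2)cc1F`, lacks the large core shared by compounds 1 and 2 but carries the 4-fluorophenyl group; in this assay compound 3 gives 62.9%, a number beyond the scatter below compound 2.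

Compound 4, `CN(C)C(=O)c1cc2cnc(Nc3ccc(NC(=O)C4(C(=O)Nc5ccc(F)cc5)CC4)cc3)nc2n1C1CCCC1`, is compound 2 with one change: fluoro in place of bromo on an aromatic carbon. Going by the values given here, the only measured step at this position, from compound 1 to compound 2, replaced 3-hydroxyphenyl with 4-bromophenyl and moved the number by a number 1.5 percentage points higher from compound 1 to compound 2 (within the scatter), so the aromatic group on that amide-type nitrogen has not yet mattered. Compound 3 shows that a 4-fluorophenyl group is compatible with growth inhibition, but its different core makes it no direct guide. The step from compound 2 to compound 4 is therefore expected to be a number 3.4 percentage points lower from compound 2 to compound 4 (within the scatter), nothing beyond the scatter. Compound 4 is estimated to give 93% in this assay, with a range from 84% to 99%.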

Compound 4, percent growth inhibition at one concentration: 102%
Compound 4: middle estimate off by 9 percentage points, on the low side; measured number above the stated range.
By their numbers in this assay, from the lowest: compound 3; then compounds 1, 2 and 4 (each within the scatter of the next).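

Fluoro in place of bromo, para to a large group on this ring, gives a number 5.6 percentage points higher from compound 2 to compound 4 (within the scatter) in this assay, so the two halogens cannot be told apart at this position on the shared core. The other step, with 4-fluorophenyl in place of 3-hydroxyphenyl, is a number 7.1 percentage points higher from compound 1 to compound 4 (within the scatter) and adds a second comparison that stays within the scatter, which means that 3-hydroxyphenyl, 4-bromophenyl and 4-fluorophenyl on this amide-type nitrogen now all give numbers that cannot be separated, with none of the three standing out as better or worse. No measurement is at hand that could explain this flat picture.

From the compounds shown here alone, all of these numbers come from a single concentration and sit close to the top of the read-out, so it remains open whether compounds 1, 2 and 4 would still look alike at lower concentrations. Going by these compounds, it is also open whether this ring would accept very different groups in the same place, such as an amine, a carboxylic acid or a longer chain, or whether the aromatic ring itself could be replaced by a plain alkyl chain.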